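Replacing Iodine with Furan-2-yl on a Nucleoside Core

This account rests on a few compounds, and the source may have more. Where it says the series, first, only, none or still open, it means among the compounds named here.

Compound 1 `COc1ncnc2c1c(-c1ccoc1)cn2[C@@H]1O[C@H](CO)[C@@H](O)[C@H]1O`: 110 nM
Compound 2 `COc1ncnc2c1c(I)cn2[C@@H]1O[C@H](CO)[C@@H](O)[C@H]1O`: 1150 nM

Of the compounds shown here, two that share a core have been measured in a functional assay on CCRF-CEM cells (Homo sapiens), read by MTT assay, with a stated time of 72 h; a lower number here means a stronger inhibitor, a higher number a weaker inhibitor. Compound 1 `COc1ncnc2c1c(-c1ccoc1)cn2[C@@H]1O[C@H](CO)[C@@H](O)[C@H]1O` carries a furan-3-yl group on an aromatic carbon and gives 110 nM. Compound 2 `COc1ncnc2c1c(I)cn2[C@@H]1O[C@H](CO)[C@@H](O)[C@H]1O` carries iodo at the same place and gives 1150 nM. This makes compound 2 the weaker of the two, the step being a 10-fold higher number from compound 1 to compound 2 (1.02 log units; beyond the scatter).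

Compound 3 `COc1ncnc2c1c(-c1ccco1)cn2[C@@H]1O[C@H](CO)[C@@H](O)[C@H]1O` has not yet been measured. It differs from compound 2 in one place: furan-2-yl in place of iodo on an aromatic carbon. Among the measured compounds shown here, the only measured step that bears on this change is the one from compound 1 to compound 2, where a furan ring was exchanged for iodo and the number rose by a 10-fold higher number from compound 1 to compound 2 (1.02 log units; beyond the scatter). Compound 3 puts a furan ring back in the same place, though attached through a different ring carbon. A step of similar size in the opposite direction is therefore expected, a 7.7-fold lower number from compound 2 to compound 3 (0.88 log units; beyond the scatter), and compound 3 is estimated to give 150 nM, with a range from 50 nM to 600 nM.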

Compound 3, half-maximal inhibitory concentration: 20 nM
For compound 3 the middle estimate is 7.5-fold (0.88 log units) above the measured one, and the stated range ends above it.
By their numbers in this assay, from the lowest: compound 3; then compound 1; then compound 2.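

In this assay, furan-2-yl in place of iodo on this aromatic carbon gives a 58-fold lower number from compound 2 to compound 3 (1.76 log units; beyond the scatter) and so shows that a second furan ring can also far outdo the iodo compound at this position. The more telling result is the comparison between the two furan compounds, which have the same atoms and differ only in which ring carbon is attached to the shared core: furan-2-yl in place of furan-3-yl gives a 5.5-fold lower number from compound 1 to compound 3 (0.74 log units; beyond the scatter) and this difference lies beyond the scatter. Among the compounds shown here, the earlier pair could show only that a furan-3-yl group outperforms iodo, whereas these three compounds show that the point of attachment of the ring also matters here, so the two furans are not interchangeable.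

Nothing measured here accounts for the gap between the two furan compounds or for the gap between either of them and the iodo compound.

From the compounds shown here alone, it remains open whether the ring oxygen is needed for this result, and how a thiophene-2-yl group, with sulfur in that ring, or a phenyl ring, an amine or a short alkyl chain such as ethyl would compare on the same carbon.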